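Replacing the trimethoxyphenyl with a dimethylaminophenyl

The source may report more compounds than this note shows. Statements on the series, on what has been measured and on what is new or still open speak of the compounds shown alone.

Going by the values given here, in a functional assay on LNCaP cells (Homo sapiens) for antiproliferative activity, read by sulforhodamine B assay (a lower number here means a stronger inhibitor, a higher number a weaker inhibitor), compound 3 `CCCCCCCCCCCCCCCCCCNC(=O)[C@@H]1CSC(c2cc(OC)c(OC)c(OC)c2)N1` gives 820 nM, the lowest of the three numbers so far. Compound 1 `CCCCCCCCCCCCCCCCCCNC(=O)[C@@H]1CSC(c2cccc(O)c2)N1` gives 1700 nM and compound 2 `CCCCCCCCCCCCCCCCCCNC(=O)[C@@H]1CSC(c2ccc(OC)cc2)N1` gives 2100 nM; both a 2.1-fold lower number from compound 1 to compound 3 (0.32 log units; beyond the scatter) and a 2.6-fold lower number from compound 2 to compound 3 (0.41 log units; beyond the scatter) accompany the entry of the trimethoxyphenyl group, while a 1.2-fold higher number from compound 1 to compound 2 (0.09 log units; within the scatter). Compound 4 `CCCCCCCCCCCCCCCCCCNC(=O)[C@@H]1CSC(c2ccc(N(C)C)cc2)N1` differs from compound 3 in one place: 4-(dimethylamino)phenyl in place of 3,4,5-trimethoxyphenyl on a saturated ring carbon. This change removes the group whose entry lowered the number in the two steps above, so a modest step upward in this assay is expected, back toward the region of compound 1 and compound 2. Because the number fell by a 2.6-fold lower number from compound 2 to compound 3 (0.41 log units; beyond the scatter) when that group entered, compound 4 is expected to show a 2.2-fold higher number from compound 3 to compound 4 (0.34 log units; beyond the scatter). Compound 4 is therefore estimated at 1800 nM, with a range from 800 nM to 4000 nM.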

Compound 4, half-maximal inhibitory concentration: 1600 nM
Compound 4: the middle estimate sits 1.1-fold (0.05 log units) above what was measured; the measured number falls inside the stated range.
By their numbers in this assay, from the lowest: compounds 3, 4, 1 and 2 (each within the scatter of the next, the first and the last beyond it).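

In this assay, the step of a 2.0-fold higher number from compound 3 to compound 4 (0.29 log units; within the scatter) shows that 4-(dimethylamino)phenyl can replace 3,4,5-trimethoxyphenyl on this saturated ring carbon without a step beyond the scatter. Compound 4 also stays within the scatter of the other two, with a 1.3-fold lower number from compound 2 to compound 4 (0.12 log units; within the scatter) and a 1.1-fold lower number from compound 1 to compound 4 (0.03 log units; within the scatter) so, unlike compound 3 before it, it stands apart from no compound shown. Nothing measured here gives a reason for this result.

The compounds shown leave open how a carboxylic acid or a primary amine on the phenyl ring would read in this assay. They also leave open what a shorter alkyl chain on the amide would do.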